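The source may report more compounds than this note shows. Statements on the series, on what has been measured and on what is new or still open speak of the compounds shown alone.

Series notes. Compound 2 `CCc1ccc(C(=O)Nc2cccc(-c3oc4cc(-c5ccc(F)cc5)ccc4c(=O)c3O)c2)cc1` carries 4-ethylphenyl on the carbonyl carbon; in a functional assay on A549 cells (Homo sapiens) for antiproliferative activity, read by CCK-8 assay, with a stated time of 72 h (on this read-out lower numbers stand for stronger inhibition and higher numbers for weaker inhibition), compound 2 gives 18500 nM, the highest of the two numbers recorded so far. Among the measured compounds shown here, its nearest neighbour is compound 1 `COc1cccc(C(=O)Nc2cccc(-c3oc4cc(-c5ccc(F)cc5)ccc4c(=O)c3O)c2)c1`, which in this assay gives 10800 nM; the single measured step, a 1.7-fold higher number from compound 1 to compound 2 (0.23 log units; within the scatter), exchanges the group on the carbonyl carbon and stays within the scatter.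

Compound 3 `O=C(Nc1cccc(-c2oc3cc(-c4ccc(F)cc4)ccc3c(=O)c2O)c1)c1ccc([N+](=O)[O-])cc1` is not yet measured. It differs from compound 2 by nitro in place of ethyl on an aromatic carbon. For the measured compounds named here, the only step that bears on this change is the exchange of the aryl group on the carbonyl carbon, a 1.7-fold higher number from compound 1 to compound 2 (0.23 log units; within the scatter), which moved the number little. Going by the values given here, nothing measured so far separates one substituent on that ring from another beyond the scatter, so no step beyond the scatter is expected here in either direction. Compound 3 is therefore estimated at 15000 nM in this assay, within 6000 nM to 40000 nM, an expected step of a 1.2-fold lower number from compound 2 to compound 3 (0.09 log units; within the scatter).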

Compound 3, half-maximal inhibitory concentration: 2440 nM
Compound 3: the middle estimate sits 6.1-fold (0.79 log units) above what was measured; measured number outside the range, below it.
By their numbers in this assay, from the lowest: compound 3; then compounds 1 and 2 (each within the scatter of the next).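

In this assay the substituent on this ring can move the number beyond the scatter: nitro in place of ethyl, on the aromatic carbon para to a large group, gives a 7.6-fold lower number from compound 2 to compound 3 (0.88 log units; beyond the scatter). The 4-nitrophenyl group also separates from the 3-methoxyphenyl group on the same carbonyl carbon, with a 4.4-fold lower number from compound 1 to compound 3 (0.65 log units; beyond the scatter), so compound 3 stands apart from both earlier compounds, which remain within the scatter of each other. No measurement available here accounts for this change.

Going by these compounds, it remains open whether the lower number is particular to nitro or would also appear with an amine, a nitrile or a carboxylic acid at this place. Also open, on these data alone, is whether nitro would give a similar number on another carbon of the same ring.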